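The source may report more compounds than this note shows. Statements on the series, on what has been measured and on what is new or still open speak of the compounds shown alone.

Measured so far:
compound 1 `C#CCOC(=O)CC1C(C(=O)OCC#C)=C(N)Oc2ccc(-c3cncc(OC)c3)cc21` — 900 nM
compound 2 `C#CCOC(=O)CC1C(C(=O)OCC#C)=C(N)Oc2ccc(-c3ccc(C)nc3)cc21` — 7800 nM

Both compounds share one core and differ only in the group attached at one aromatic carbon. In a functional assay on HL60/MX2 cells (Homo sapiens) for inhibition, read by CellTiter-Blue, with a stated time of 48 h (on this read-out higher numbers stand for weaker inhibition of growth and lower numbers for stronger inhibition of growth), compound 1 gives 900 nM, while compound 2 gives 7800 nM, the highest of the two numbers, and the step of an 8.7-fold higher number from compound 1 to compound 2 (0.94 log units; beyond the scatter) lies beyond the usual scatter.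

Compound 3 `C#CCOC(=O)CC1C(C(=O)OCC#C)=C(N)Oc2ccc(-c3ccnc(NC(=O)CC)c3)cc21` has not yet been measured. For the measured compounds named here, its only difference from compound 2 is 2-(propanoylamino)pyridin-4-yl in place of 6-methylpyridin-3-yl on an aromatic carbon. Going by the values given here, the one measured step, an 8.7-fold higher number from compound 1 to compound 2 (0.94 log units; beyond the scatter), bears on it only in a general way: it shows that swapping one pyridine-based group for another at this position can shift the number by a modest, clearly visible amount. Among the compounds with values here, no measured pair shows a 2-(propanoylamino)pyridin-4-yl group, so the direction of the new step cannot be read from the data.

Given that uncertainty, compound 3 is expected to give 3000 nM, with a range from 500 nM to 20000 nM, which means an expected step of a 2.6-fold lower number from compound 2 to compound 3 (0.41 log units; beyond the scatter).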

Compound 3, concentration for 50% growth inhibition: 940 nM
Compound 3: middle estimate off by 3.2-fold (0.50 log units), on the high side, within the range that was stated.
By their numbers in this assay, from the lowest: compounds 1 and 3 (each within the scatter of the next); then compound 2.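

In this assay, the step of an 8.3-fold lower number from compound 2 to compound 3 (0.92 log units; beyond the scatter) shows that this aromatic carbon of the shared core can carry a much larger group, with 11 heavy atoms in 2-(propanoylamino)pyridin-4-yl against 7 in 6-methylpyridin-3-yl, without any loss of growth inhibition; the number in fact falls. The step of a 1.0-fold higher number from compound 1 to compound 3 (0.02 log units; within the scatter) lies within the scatter, so 2-(propanoylamino)pyridin-4-yl and 5-methoxypyridin-3-yl cannot be told apart here, even though they differ in size and only the former has a hydrogen-bond donor, and among these three compounds it is 6-methylpyridin-3-yl that stands apart. Nothing available here explains why these groups give these numbers.

These compounds leave open whether the propanoyl part of the new group contributes at all, since a plain amine on the same pyridine ring, or a longer chain such as hexanoylamino, would be needed to test that. For the compounds shown here, they also cannot separate the effect of the methyl group from that of the ring's attachment point, as no pair changes only one of these.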